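Extending the Chain of Compound 1 by One Unit

This account rests on a few compounds, and the source may have more. Where it says the series, first, only, none or still open, it means among the compounds named here.

For the measured compounds named here, in a toxicity assay on CHO cells (Cricetulus griseus) for cytotoxicity, read by WST assay, with a stated time of 24 h (on this read-out higher numbers stand for weaker inhibition and lower numbers for stronger inhibition), compound 1 (`CC(C)=CCCC(C)=CCNCCN`) gives 36200 nM, the only exact number among the measured compounds. Compound 2 (`CC(C)=CCCC(C)=CCNCCCN`) reads > 150000 nM, which is a limit of the assay. Compound 3 (`CC(C)=CCCC(C)=CCNCCNCCNCCN`) also reads > 150000 nM, again a limit.

Compound 4 (`CC(C)=CCC/C(C)=C\CCC(C)=CCNCCN`) differs from compound 1 by 3-methylbut-2-en-1-yl in place of hydrogen on a saturated chain carbon bound to a double-bonded chain carbon. It has 3-methylbut-2-en-1-yl in place of hydrogen on a saturated chain carbon bound to a double-bonded chain carbon.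

Two measured steps are available, an at least 4.1-fold higher number from compound 1 to compound 2 (0.61 log units; beyond the scatter) and an at least 4.1-fold higher number from compound 1 to compound 3 (0.61 log units; beyond the scatter). Both lie beyond the scatter and both lead to higher numbers. Neither changes a saturated chain carbon bound to a double-bonded chain carbon, so they bear on this change only indirectly and do not fix its size or direction.

A modest move towards stronger inhibition in this assay is nevertheless expected, with an estimated 2.4-fold lower number from compound 1 to compound 4 (0.38 log units; beyond the scatter). For compound 4 the estimated value is 15000 nM, with an expected range of 4000 nM to 60000 nM.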

Compound 4, half-maximal inhibitory concentration: 32300 nM
Beside the measured number, compound 4's estimate is 2.2-fold (0.33 log units) below it, and the stated range covers the measured number.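

In this assay, the step on adding 3-methylbut-2-en-1-yl to a saturated chain carbon bound to a double-bonded chain carbon reads a 1.1-fold lower number from compound 1 to compound 4 (0.05 log units; within the scatter), so the two compounds cannot be told apart. For the compounds shown here, this position therefore accepts a group of 5 heavy atoms with no change beyond the scatter, which the earlier compounds, all altered elsewhere, could not show. Unlike the changes leading to compounds 2 and 3, this change yields an exact number rather than a limit of the assay: the limit of > 150000 nM in this assay, at which 2 of the 4 values shown sit.

The compounds shown leave open whether a methyl group, a longer chain or a carboxylic acid on this same carbon would also stay within the scatter of compound 1. They also leave open how 3-methylbut-2-en-1-yl would read on compounds 2 and 3, whose readings are limits.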